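Swapping the Sulfamoylthiophene for a Tetrazole on the Oxazole

A few compounds are considered here, and "the series" means these few. Any claim that something is new, unique, unknown or untested is made for them only; others in the source may bear on it.

Compound 1 `COc1ccccc1-c1cnc(C(=O)CCCCCCc2ccccc2)o1`: 400 nM
Compound 2 `O=C(O)c1ccc(-c2cnc(C(=O)CCCCCCc3ccccc3)o2)cc1`: 60 nM
Compound 3 `NS(=O)(=O)c1ccc(-c2cnc(C(=O)CCCCCCc3ccccc3)o2)s1`: 3 nM

In an assay (Rattus norvegicus) for inhibition of Fatty-acid amide hydrolase 1 (Homo sapiens) (on this read-out higher numbers stand for weaker inhibition and lower numbers for stronger inhibition), compound 3 gives the lowest number of the three, with a 20-fold lower number from compound 2 to compound 3 (1.30 log units; beyond the scatter) and a 130-fold lower number from compound 1 to compound 3 (2.12 log units; beyond the scatter), so it is the strongest inhibitor measured here. Compound 4 `O=C(CCCCCCc1ccccc1)c1ncc(-c2nnn[nH]2)o1` differs from compound 3 in one place: 1H-tetrazol-5-yl in place of 5-sulfamoylthiophen-2-yl on an aromatic carbon. Going by the values given here, no measured step swaps in a tetrazole, but the two steps into compound 3 show that the sulfamoylthiophene carries most of the gain, and compound 2 with an acid-bearing ring sits well above it. A group that is much smaller and lacks the thiophene is therefore expected to lose ground, giving a 33-fold higher number from compound 3 to compound 4 (1.52 log units; beyond the scatter) in this assay. Compound 4 is estimated at 100 nM, between 20 nM and 600 nM.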

Compound 4, inhibition constant: 63 nM
Compound 4: the middle estimate sits 1.6-fold (0.20 log units) above what was measured; the measured number falls inside the stated range.
By their numbers in this assay, from the lowest: compound 3; then compounds 2 and 4 (each within the scatter of the next); then compound 1.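

At this carbon next to the ring oxygen, the small 1H-tetrazol-5-yl keeps pace with the larger 4-carboxyphenyl, with a 1.1-fold higher number from compound 2 to compound 4 (0.02 log units; within the scatter), and improves on 2-methoxyphenyl, with a 6.3-fold lower number from compound 1 to compound 4 (0.80 log units; beyond the scatter). It still falls short of 5-sulfamoylthiophen-2-yl, with a 21-fold higher number from compound 3 to compound 4 (1.32 log units; beyond the scatter), even though both groups have the same counts of hydrogen-bond donors and acceptors, so those counts alone do not set the number here. No measurement available here explains these differences.

Still open, going by these compounds, is how a plain thiophene, without the sulfamoyl group, or an amine at this carbon would compare.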